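Amide N-acyl variation in dodecylamide threonine series

This account rests on a few compounds, and the source may have more. Where it says the series, first, only, none or still open, it means among the compounds named here.

Compound 1 `CCCCCCCCCCCCNC(=O)[C@@H](NC(=O)c1ccccc1)[C@@H](C)O` carries a phenyl group on the carbonyl carbon of the amide-type nitrogen; in a functional assay on MCF7 cells (Homo sapiens) for cytotoxicity, read by MTT assay, with a stated time of 48 h (on this read-out lower numbers stand for stronger inhibition and higher numbers for weaker inhibition), compound 1 gives 36600 nM. Compound 2 `CCCCCCCCCCCCNC(=O)[C@@H](NC(=O)c1cc2ccccc2n1C)[C@@H](C)O` replaces that phenyl with 1-methyl-1H-indol-2-yl, and in this assay compound 2 gives 31300 nM. The step of a 1.2-fold lower number from compound 1 to compound 2 (0.07 log units; within the scatter) lies within the scatter, so the two values cannot be ordered and compound 2 stands simply as one of two numbers, with compound 1 as its nearest neighbour.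

Compound 3 `CCCCCCCCCCCCNC(=O)[C@@H](NC(=O)/C=C/c1ccccc1)[C@@H](C)O` is the next variation at the same position: 2-phenylethenyl in place of 1-methyl-1H-indol-2-yl on a carbonyl carbon. Among the compounds with values here, the only measured step bearing on this site is the one from compound 1 to compound 2, which exchanged one aromatic group for another on the carbonyl carbon and stayed within the scatter. One such step gives no footing for a shift in either direction, and the change to 2-phenylethenyl is of comparable scope. For compound 3 no step beyond the scatter is therefore expected, a 1.1-fold higher number from compound 2 to compound 3 (0.02 log units; within the scatter). In this assay compound 3 is estimated at 33000 nM, within a range of 15000 nM to 72000 nM.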

Compound 3, half-maximal inhibitory concentration: > 200000 nM
Compound 3: a limit, no number; the forecaster's own chance of this, stated with the estimate: 10%; at least 6.0-fold (0.78 log units) between middle value and limit.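

In this assay, this position on the carbonyl carbon proves not to be indifferent to the group it carries: phenyl and 1-methyl-1H-indol-2-yl stay within the scatter of each other, while 2-phenylethenyl gives an at least 6.3-fold higher number from compound 2 to compound 3 (0.80 log units; beyond the scatter) and also an at least 5.4-fold higher number from compound 1 to compound 3 (0.73 log units; beyond the scatter). Compound 3 stands at a limit of the assay and not at a number: the limit of > 200000 nM in this assay, at which 1 of the 3 values shown sits. Within the data shown here, both steps are therefore lower bounds on the size of the change, and 2-phenylethenyl is the only one of the three groups with a double bond outside aromatic rings, although three compounds cannot tie the step to that double bond alone.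

Whether the double bond itself or the added carbons of the group account for the step remains open, and a saturated 2-phenylethyl group on the same carbonyl carbon would separate the two. Also open, on these data alone, is whether an amine or a carboxylic acid on the phenyl ring of 2-phenylethenyl would bring the number back to the range of compound 1 and compound 2.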